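From 2-fluorophenyl to phenyl on a shared core

The compounds below may be only part of what the source reports. "The series", "measured", "known", "first", "only" and "open" are said of these compounds alone.

In a functional assay on PANC-1 cells (Homo sapiens) for inhibition, read by MTT assay, with a stated time of 24 h (a higher number here means a weaker inhibitor, a lower number a stronger inhibitor), compound 1 (`CC1(C)[C@H]2CC[C@]1(C)N(Cc1cn(-c3ccccc3Br)nn1)C(=O)C2`) gives 280 nM and compound 2 (`CC1(C)[C@H]2CC[C@]1(C)N(Cc1cn(-c3ccccc3F)nn1)C(=O)C2`) gives 150 nM so the two stand within the scatter of each other. Compound 3 (`CC1(C)[C@H]2CC[C@]1(C)N(Cc1cn(-c3ccccc3)nn1)C(=O)C2`) carries hydrogen in place of fluoro on an aromatic carbon and is still unmeasured. Among the measured compounds shown here, the one measured step at this carbon, fluoro in place of bromo, is a 1.9-fold lower number from compound 1 to compound 2 (0.27 log units; within the scatter) and so no step beyond the scatter is expected in this assay here. The expected step is a 1.3-fold higher number from compound 2 to compound 3 (0.12 log units; within the scatter) in size. For compound 3 the estimate is 200 nM with 80 nM to 500 nM as the expected range.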

Compound 3, half-maximal inhibitory concentration: 160 nM
For compound 3 the middle estimate is 1.3-fold (0.10 log units) above the measured one; low and high end bracket the measured number.
By their numbers in this assay, from the lowest: compounds 2, 3 and 1 (each within the scatter of the next).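

Taking the halogen away altogether leaves the number in this assay within the scatter, with a 1.1-fold higher number from compound 2 to compound 3 (0.03 log units; within the scatter) and a 1.8-fold lower number from compound 1 to compound 3 (0.24 log units; within the scatter). Hydrogen, fluoro and bromo at this aromatic carbon therefore cannot be told apart in this assay, and compound 3 shows that a halogen here is not required for a number in this range. Nothing available explains this result. The compounds shown leave open whether an amine or a carboxylic acid at this carbon would give a step beyond the scatter.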